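A few compounds are considered here, and "the series" means these few. Any claim that something is new, unique, unknown or untested is made for them only; others in the source may bear on it.

Compound 2 `Cc1cc(Nc2ccn(Cc3cccc4ccccc34)n2)n2nc(SCc3ccc(Br)cc3)nc2n1` gives 5660 nM in a functional assay on PC-9 cells (Homo sapiens) for inhibition, read by MTT assay, with a stated time of 72 h (a lower number here means a stronger inhibitor, a higher number a weaker inhibitor), and compound 1 `Cc1cc(Nc2cc(-c3ccccc3)[nH]n2)n2nc(SCCCc3ccccc3)nc2n1` gives 5030 nM in this assay, the two values lying within the usual scatter of each other. Compound 3 `CCCSc1nc2nc(C)cc(Nc3cc(-c4ccccc4)[nH]n3)n2n1` reaches only the limit > 50000 nM in this assay. For the measured compounds named here, the one measured step, an at least 9.9-fold higher number from compound 1 to compound 3 (0.99 log units; beyond the scatter), sits on the sulfur-linked chain, far from the place changed here. Compound 4 `Cc1cc(Nc2ccn(Cc3ccc(C(F)(F)F)cc3)n2)n2nc(SCc3ccc(Br)cc3)nc2n1` differs from compound 2 by 4-(trifluoromethyl)phenyl in place of naphthalen-1-yl on a saturated chain carbon bound to an aromatic nitrogen. Going by the values given here, no measured step touches that position, so compound 4 is expected to stay within the scatter of compound 2, a step of a 1.0-fold lower number from compound 2 to compound 4 (0.01 log units; within the scatter). Compound 4 is therefore estimated at 5500 nM, between 2000 nM and 16000 nM, in this assay.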

Compound 4, half-maximal inhibitory concentration: 5580 nM
Compound 4: middle estimate off by 1.0-fold (0.01 log units), on the low side, within the range that was stated.
By their numbers in this assay, from the lowest: compounds 1, 4 and 2 (each within the scatter of the next). At a limit, above all of these: compound 3.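

For the compounds shown here, at this position, on a saturated chain carbon bound to an aromatic nitrogen, the earlier compounds gave no step, and a 1.0-fold lower number from compound 2 to compound 4 (0.01 log units; within the scatter) is the first reading in this assay. Thus 4-(trifluoromethyl)phenyl, with one six-membered aromatic ring of carbon only, and naphthalen-1-yl, with 2 such rings, cannot be told apart in this pair. Nothing in the data shown bears on why these two groups give such close values. Going by these compounds, whether an amine or a carboxylic acid in place of either group would also leave the value within the scatter remains open.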